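Phenyl in Place of Propyl on Compound 2

The compounds below may be only part of what the source reports. "The series", "measured", "known", "first", "only" and "open" are said of these compounds alone.

Compound 1 (`CCCCCCCCNC1=CC(=O)C=C(C[C@]2(C)[C@@H](C)CC[C@]3(C)C(C)=CCC[C@@H]23)C1=O`): 17000 nM
Compound 2 (`CCCCNC1=CC(=O)C=C(C(C)(C)C)C1=O`): 11000 nM
Compound 3 (`CCCCNC1=CC(=O)C(C[C@]2(C)[C@@H](C)CC[C@]3(C)C(C)=CCC[C@@H]23)=CC1=O`): > 100000 nM

In an ADME assay on HaCaT cells (Homo sapiens) for cytotoxicity, read by MTT assay, with a stated time of 72 h (a lower number here means a stronger inhibitor, a higher number a weaker inhibitor), compound 2 gives 11000 nM and stands within the scatter of compound 1 at 17000 nM with no order between the two. Compound 3 gives > 100000 nM as a limit of the assay and not a number.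

Compound 4 (`CC(C)(C)C1=CC(=O)C=C(NCc2ccccc2)C1=O`) has not yet been measured. Compared with compound 2 it has phenyl in place of propyl on a saturated chain carbon bound to an amine nitrogen. Among the compounds with values here, no measured pair differs in one place only. In this assay no step beyond the scatter is expected in either direction. The expected step is a 1.1-fold higher number from compound 2 to compound 4 (0.04 log units; within the scatter) in size. Compound 4 is expected to give 12000 nM (estimated range 4000 nM to 40000 nM).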

Compound 4, half-maximal inhibitory concentration: 21000 nM
Beside the measured number, compound 4's estimate is 1.8-fold (0.24 log units) below it, and the stated range covers the measured number.
By their numbers in this assay, from the lowest: compounds 2, 1 and 4 (each within the scatter of the next). At a limit, above all of these: compound 3.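

Phenyl in place of propyl on a saturated chain carbon bound to an amine nitrogen gives, in this assay, a 1.9-fold higher number from compound 2 to compound 4 (0.28 log units; within the scatter) and thus no step beyond the scatter. Within the data shown here, this is the first pair here that differs in one place, and it shows that this position takes a six-membered aromatic ring of carbon only with the number staying within the scatter of compound 2. Nothing measured here bears on a cause for this step.

As far as these compounds go, whether an amine or a carboxylic acid at the end of this chain would stay within the scatter remains open. So does whether a longer chain on the core of compound 2 would do so.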